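A few compounds are considered here, and "the series" means these few. Any claim that something is new, unique, unknown or untested is made for them only; others in the source may bear on it.

Compound 1 `O=C(CSc1nc(Cc2c(Cl)cccc2Cl)cc(=O)[nH]1)c1ccccc1` gives > 12000 nM
Compound 2 `Cc1c(Cc2c(Cl)cccc2Cl)nc(SCC(=O)c2ccccc2)[nH]c1=O` gives > 60000 nM
Compound 3 `CCc1c(Cc2c(Cl)cccc2Cl)nc(SCC(=O)c2ccccc2)[nH]c1=O` gives > 52000 nM
Compound 4 `CC(C)c1c(Cc2c(Cl)cccc2Cl)nc(SCC(=O)c2ccccc2)[nH]c1=O` is not yet measured

In an ADME assay on MT4 cells (Homo sapiens) for cytotoxicity, read by MTT assay (a lower number here means that less compound is tolerated, a higher number that more compound is tolerated), compound 3 gives > 52000 nM as a limit and not a number. The values of compound 1 and compound 2 are limits too, so compound 3 cannot be ranked against either. Compound 4 adds the change methyl in place of hydrogen on a saturated chain carbon bound to an aromatic carbon and a saturated chain carbon to compound 3, turning ethyl to isopropyl. The closest measured change is a step that the two limits leave unreadable from compound 2 to compound 3 and the steps a step that the two limits leave unreadable from compound 1 to compound 2 and a step that the two limits leave unreadable from compound 1 to compound 3 also bear on it, yet none of the three has a readable size. No step beyond the usual scatter is therefore expected in this assay here. The expected change is an at least 1.0-fold lower number from compound 3 to compound 4 (0.01 log units; that floor lies within the scatter) as a rough estimate. Compound 4 is estimated at 50000 nM within an expected range from 20000 nM to 100000 nM and may well return only a limit.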

Compound 4, half-maximal cytotoxic concentration: > 56000 nM
Compound 4 was reported as a limit; the forecaster's own chance of this, stated with the estimate: 80%; at least 1.1-fold (0.04 log units) between middle value and limit.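

Within the data shown here, compound 4, like compounds 1, 2 and 3, is reported only as a limit, so no step among them can be read in this assay. The compounds shown leave open at what concentration any of them harms the cells, and whether changing hydrogen, methyl, ethyl or isopropyl alters it.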